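Three Limits and a Fourth Compound Awaiting Measurement

The source may hold more compounds than are shown below. What is called first, only, known or untested is meant among the compounds shown, and "the series" means these compounds.

Measured so far:
compound 1 `O=c1n(Cc2nc3nc(Cl)ccc3n2CCCCO)c2cnccc2n1C1CC1` gives > 50000 nM
compound 2 `O=c1n(Cc2cc3cc(Cl)ccc3n2CCCC(F)(F)F)c2cnccc2n1C1CC1` gives > 50000 nM
compound 3 `O=c1n(Cc2cc3ccc(Cl)cc3n2CCCCO)c2cnccc2n1C1CC1` gives > 50000 nM

In an ADME assay on HeLa cells (Homo sapiens) for cytotoxicity, read by ATP content, with a stated time of 3 days (a higher number here means that more compound is tolerated, a lower number that less compound is tolerated), compound 2 stands at the limit of the assay: its value is a limit, not a number. Compound 1 sits at the same limit. Compound 3 sits at the same limit as well. Within the data shown here, all three therefore share the position described by the limit of > 50000 nM in this assay, at which 3 of the 3 values shown sit, and no step between measured compounds can be computed from them, since none of them yields a number.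

The next compound, compound 4 `NC(=O)CCCn1c(Cn2c(=O)n(C3CC3)c3ccncc32)cc2cc(Cl)ccc21`, differs from compound 2 in one place: carbamoyl in place of trifluoromethyl on a saturated chain carbon, three bonds along the chain from an aromatic nitrogen. Among the measured compounds shown here, with no measured step to lean on, and with compound 2 itself giving only a limit in this assay, there is no basis to expect a movement in either direction beyond the scatter. Compound 4 is therefore estimated at 50000 nM, within a range of 30000 nM to 100000 nM, meaning an expected step of a number no higher from compound 2 to compound 4 (the limit leaves the size open).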

Compound 4, half-maximal cytotoxic concentration: > 50000 nM
Compound 4: a limit, no number; the forecaster's own chance of this, stated with the estimate: 85%; the middle value sits exactly at the limit.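

In this assay compound 4 gives > 50000 nM, a limit and not a number. Among these compounds, compound 2 also gives only a limit, so no step between compound 2 and compound 4 can be read. The compounds shown leave open at what concentration any of them becomes cytotoxic, and whether carbamoyl in place of trifluoromethyl changes that at all: the limit of > 50000 nM in this assay, at which 4 of the 4 values shown sit.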